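Aryl ketone variation on the shared core

This account rests on a few compounds, and the source may have more. Where it says the series, first, only, none or still open, it means among the compounds named here.

Compound 2 `COc1cc(-c2nnc3n2NC(c2ccco2)C(C(=O)c2ccccc2F)S3)cc(OC)c1OC` stands level with compound 1 `COc1cc(-c2nnc3n2NC(c2ccco2)C(C(=O)c2cccs2)S3)cc(OC)c1OC`: in a functional assay on A549 cells (Homo sapiens) for cytotoxicity, read by MTT assay, with a stated time of 48 h (a higher number here means a weaker inhibitor, a lower number a stronger inhibitor), compound 1 gives 78700 nM, and in this assay compound 2 gives 78700 nM, the step of no change at the digits printed from compound 1 to compound 2 (within the scatter) lying within the scatter. Compound 3 `COc1cccc(C(=O)C2Sc3nnc(-c4cc(OC)c(OC)c(OC)c4)n3NC2c2ccco2)c1` carries 3-methoxyphenyl in place of 2-fluorophenyl on a carbonyl carbon. Going by the values given here, the one measured step that bears on this change, no change at the digits printed from compound 1 to compound 2 (within the scatter), exchanged the aryl group on the carbonyl carbon and moved nothing; the present change alters the same group only, so no step beyond the scatter is expected. Compound 3 is estimated at 78700 nM, range 39000 nM to 160000 nM, an expected step of no change at the digits printed from compound 2 to compound 3 (within the scatter).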

Compound 3, half-maximal inhibitory concentration: > 100000 nM
Compound 3: only a limit was reported (the forecaster's own chance of this, stated with the estimate: 30%); middle value at least 1.2-fold (0.10 log units) away from the limit.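

With 3-methoxyphenyl on the carbonyl carbon, this assay gives only a limit for compound 3, > 100000 nM. The change reads as an at least 1.2-fold higher number from compound 2 to compound 3 (0.10 log units; that floor lies within the scatter), and as an at least 1.2-fold higher number from compound 1 to compound 3 (0.10 log units; that floor lies within the scatter); both are floors within the scatter, so the change at this position is not shown to exceed the scatter, and its true size stays unread. The limit itself sets this bound: the limit of > 100000 nM in this assay, at which 1 of the 3 values shown sits.

Going by these compounds, whether a phenyl ring carrying an amine or a carboxylic acid on this carbonyl carbon would lower the number stays open. So does the outcome of replacing the furan-2-yl group on the shared core.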